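This account rests on a few compounds, and the source may have more. Where it says the series, first, only, none or still open, it means among the compounds named here.

Compound 2 `COc1ccc(NC(=O)Oc2cc(=O)n(CCCO)c3c2CC(CC=C(C)C)C(C)(C)C3)cc1` gives the lowest of the two numbers seen so far in a functional assay on PANC-1 cells (Homo sapiens) for inhibition, read by MTT assay, with a stated time of 24 h, tested at 10 uM (a higher number here means more inhibition at the concentration tested (going by the name of the read-out), a lower number less inhibition), namely 0%. The nearest measured point is compound 1 `CC(C)=CCC1Cc2c(OCCCNC(=O)c3ccco3)cc(=O)n(CCCO)c2CC1(C)C`, which in this assay gives 4.3%; the step of a number 4.3 percentage points lower from compound 1 to compound 2 (within the scatter) lies within the scatter, so the two cannot be told apart. Compound 3 `COc1cccc(NC(=O)Oc2cc(=O)n(CCCO)c3c2CC(CC=C(C)C)C(C)(C)C3)c1` is the next compound to be measured. Its difference from compound 2 is 3-methoxyphenyl in place of 4-methoxyphenyl on an amide-type nitrogen, a change placed on the amide-type nitrogen of the carbamate. Going by the values given here, no measured step touches the methoxyphenyl group itself; the only available step, from compound 1 to compound 2, replaced the whole side chain and still stayed within the scatter, so nothing here points to a sizeable shift. Compound 3 is therefore expected to show essentially no step beyond the scatter, with a number 3 percentage points higher from compound 2 to compound 3 (within the scatter) as the estimated change. Compound 3 is estimated at 3%, within a range from 0% to 13%.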

Compound 3, a percentage reported as inhibition, at one concentration (the size of the read-out at that concentration, not a potency): 0%
Compound 3: the middle estimate sits 3 percentage points above what was measured; measured number inside the range.
By their numbers in this assay, from the lowest: compounds 2, 3 and 1 (each within the scatter of the next).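

In this assay, the swap of 3-methoxyphenyl for 4-methoxyphenyl on an amide-type nitrogen gives no change at the digits printed from compound 2 to compound 3 (within the scatter), so at this position these two methoxyphenyl groups cannot be told apart, something the earlier exchange of a whole side chain could not show. The exchange of the 3-(((furan-2-yl)carbonyl)amino)propyl group for (3-methoxyphenyl)carbamoyl gives a number 4.3 percentage points lower from compound 1 to compound 3 (within the scatter), so this side-chain exchange also stays within the scatter, whichever of the two methoxyphenyl groups is carried. No measurement at hand offers an explanation for these results.

The compounds shown leave open whether any group on this amide-type nitrogen can give a step beyond the scatter in this assay. Going by these compounds, an amine or a carboxylic acid on the phenyl ring, or a longer chain in place of the methoxy group, remains untested here.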